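Thiophene to pyridine on the dienone oxime ether chain

The source may report more compounds than this note shows. Statements on the series, on what has been measured and on what is new or still open speak of the compounds shown alone.

Measured so far:
compound 1 `Clc1ccccc1COc1ccccc1/C=C/C(/C=C/c1ccccn1)=N/Oc1ncnc2ccccc12`: 95.7%
compound 2 `Fc1ccccc1COc1ccc(/C=C/C(/C=C/c2ccccn2)=N/Oc2ncnc3cc(Cl)ccc23)cc1`: 81.1%
compound 3 `Clc1ccc(COc2ccc(/C=C/C(/C=C/c3cccs3)=N/Oc3ncnc4ccccc34)cc2)cc1`: 89.3%

In a functional assay on SMMC-7721 cells (Homo sapiens) for inhibition, read by MTT assay, with a stated time of 72 h, tested at 1 uM (a lower number here means a weaker effect, a higher number a stronger effect of the compound at the concentration tested), compound 1 gives 95.7%, compound 2 gives 81.1% and compound 3 gives 89.3%. The number for compound 3 lies within the scatter of both of the others, so none of the three can be set apart from another on this assay.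

Compound 4 `Clc1ccc(COc2ccc(/C=C/C(/C=C/c3ccccn3)=N/Oc3ncnc4ccccc34)cc2)cc1` differs from compound 3 in one place: pyridin-2-yl in place of thiophen-2-yl on a double-bonded chain carbon bound to a double-bonded chain carbon. Compounds 1 and 2 already carry the pyridin-2-yl group, and their values sit within the scatter of compound 3. The step from compound 3 to compound 4 is therefore expected to be none beyond the scatter, a number 0.3 percentage points lower from compound 3 to compound 4 (within the scatter). Compound 4 is estimated at 89%, with a range from 76% to 97%.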

Compound 4, a percentage reported as inhibition, at one concentration (the size of the read-out at that concentration, not a potency): 91.2%
For compound 4 the middle estimate is 2.2 percentage points below the measured one, within the range that was stated.
By their numbers in this assay, from the lowest: compounds 2, 3, 4 and 1 (each within the scatter of the next, the first and the last beyond it).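

In this assay, for the compounds shown here, the exchange of thiophen-2-yl for pyridin-2-yl on a double-bonded chain carbon bound to a double-bonded chain carbon gives a number 1.9 percentage points higher from compound 3 to compound 4 (within the scatter), the first comparison at this place that changes nothing else. A five-membered aromatic ring with sulfur and a six-membered aromatic ring with nitrogen therefore cannot be told apart here at the one concentration tested. No available measurement bears on why the two rings read alike.

The compounds shown leave open whether phenyl or an amine at this place would give a similar read-out. They also leave open whether thiophen-2-yl and pyridin-2-yl would still read alike at other concentrations.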